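The source may hold more compounds than are shown below. What is called first, only, known or untested is meant among the compounds shown, and "the series" means these compounds.

In a functional assay on OVCAR-8 cells (Homo sapiens) for antiproliferative activity (on this read-out lower numbers stand for stronger inhibition and higher numbers for weaker inhibition), compound 1 `CNC(=O)C[C@@H]1C[C@@H](c2ccc(Cl)c(Cl)c2)[C@H](NC(=O)c2cc(-c3c(Cl)cnn3C)c(Cl)o2)CN1` gives 1130 nM and compound 2 `Cn1ncc(Cl)c1-c1cc(C(=O)N[C@@H]2CN[C@H](CCCO)C[C@H]2c2ccc(Cl)c(Cl)c2)oc1Cl` gives 600 nM, while compound 3 `Cn1ncc(Cl)c1-c1cc(C(=O)N[C@@H]2CN[C@H](CCn3cncn3)C[C@H]2c2ccc(Cl)c(Cl)c2)oc1Cl` gives 1560 nM as its value. Among the measured compounds shown here, compound 3 sits within the scatter of compound 1, and only the step of a 2.6-fold higher number from compound 2 to compound 3 (0.41 log units; beyond the scatter) goes beyond it. Compound 4 `Cn1ncc(Cl)c1-c1cc(C(=O)N[C@@H]2CN[C@H](CC(N)=O)C[C@H]2c2ccc(Cl)c(Cl)c2)oc1Cl` carries carbamoyl in place of (1H-1,2,4-triazol-1-yl)methyl on a saturated chain carbon bound to a saturated ring carbon. The closest evidence is the step of a 1.4-fold higher number from compound 1 to compound 3 (0.14 log units; within the scatter) at that same place, where methylcarbamoyl gives way to (1H-1,2,4-triazol-1-yl)methyl. The step of a 1.9-fold lower number from compound 1 to compound 2 (0.27 log units; within the scatter) at that place also stays small. No step beyond the scatter is therefore expected in this assay, and the estimated move is a 1.7-fold lower number from compound 3 to compound 4 (0.24 log units; within the scatter) at most. For compound 4 the expected value is 900 nM within an estimated range from 400 nM to 2000 nM overall.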

Compound 4, half-maximal inhibitory concentration: 1000 nM
The estimate for compound 4 lay 1.1-fold (0.05 log units) below the measured number; the measured number falls inside the stated range.
By their numbers in this assay, from the lowest: compounds 2, 4, 1 and 3 (each within the scatter of the next, the first and the last beyond it).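

In this assay, carbamoyl at this place, on a saturated chain carbon bound to a saturated ring carbon, leaves every comparison within the scatter: a 1.6-fold lower number from compound 3 to compound 4 (0.19 log units; within the scatter); a 1.7-fold higher number from compound 2 to compound 4 (0.22 log units; within the scatter); a 1.1-fold lower number from compound 1 to compound 4 (0.05 log units; within the scatter). The last step also shows that hydrogen in place of methyl on the amide-type nitrogen has no readable effect here. No measurement at hand accounts for these steps. From the compounds shown here alone, whether an amine or a carboxylic acid at this place would give a step beyond the scatter remains open, as does the effect of a longer chain bearing the carbamoyl.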